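Moving the Halogen on a Weak Inhibitor

The compounds below may be only part of what the source reports. "The series", "measured", "known", "first", "only" and "open" are said of these compounds alone.

compound 1 `N#CC1=C(N)OC(c2c[nH]c3ccccc23)=C(C#N)C1c1ccccc1Cl` — > 1000 ug/mL
compound 2 `COc1cc(Br)c(C2C(C#N)=C(N)OC(c3c[nH]c4ccccc34)=C2C#N)cc1OC` — 880 ug/mL

Compound 1 (`N#CC1=C(N)OC(c2c[nH]c3ccccc23)=C(C#N)C1c1ccccc1Cl`) stands at the edge of what a functional assay (a lower number here means a stronger inhibitor, a higher number a weaker inhibitor), can report. In this assay compound 1 gives only a limit, > 1000 ug/mL, and not a number. Compound 2 (`COc1cc(Br)c(C2C(C#N)=C(N)OC(c3c[nH]c4ccccc34)=C2C#N)cc1OC`) gives 880 ug/mL in this assay, a weak reading as well. Within the data shown here, with only these two values, and one of them a limit (the limit of > 1000 ug/mL in this assay, at which 1 of the 2 values shown sits), no measured step between compounds of this kind is available.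

Compound 3 (`N#CC1=C(N)OC(c2c[nH]c3ccccc23)=C(C#N)C1c1ccc(Br)cc1`) has not yet been measured. It differs from compound 1 in one place: 4-bromophenyl in place of 2-chlorophenyl on a saturated ring carbon. Since nothing measured here shows how such a change moves the read-out, compound 3 is expected to stay near where compound 1 sits, with no step beyond the usual scatter. Compound 3 is therefore estimated at 1000 ug/mL, with a range of 400 ug/mL to 2500 ug/mL, which would mean a step of a number no higher from compound 1 to compound 3 (the limit leaves the size open).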

Compound 3, half-maximal inhibitory concentration: 947 ug/mL
Beside the measured number, compound 3's estimate is 1.1-fold (0.02 log units) above it; low and high end bracket the measured number.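

On a saturated ring carbon of the shared core, 4-bromophenyl in place of 2-chlorophenyl gives an at least 1.0-fold lower number from compound 1 to compound 3 (0.02 log units; that floor lies within the scatter) in this assay. Among these compounds, this is the first step read at this position, and it shows that this exchange of one halogen-bearing phenyl group for another produces no shift that can be told from the scatter. The step remains only a floor because compound 1 has a limit and not a number: the limit of > 1000 ug/mL in this assay, at which 1 of the 3 values shown sits.

The change alters both the halogen and its place on the phenyl ring, so the compounds shown cannot separate the two, and 4-chlorophenyl or 2-bromophenyl would be needed to do so. They also leave open whether anything other than a halogen-bearing phenyl group at this carbon, such as a phenyl ring carrying an amine or a carboxylic acid, would move the read-out at all.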